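Benzylselanyl in place of methylsulfanyl on the amidine carbon

This account rests on a few compounds, and the source may have more. Where it says the series, first, only, none or still open, it means among the compounds named here.

Compound 2 `CS/C(=N\C(=O)c1cnc2ccccc2c1)NC(=O)c1cnc2ccccc2c1` gives 42200 nM in an ADME assay on MCF-10A cells (Homo sapiens) for cytotoxicity, read by MTT assay, with a stated time of 72 h; on this read-out lower numbers stand for stronger inhibition of growth and higher numbers for weaker inhibition of growth. Going by the values given here, its only neighbour on this read-out is compound 1 `C[Se]/C(=N\C(=O)c1cnc2ccccc2c1)NC(=O)c1cnc2ccccc2c1`, which gives 52100 nM in this assay; the two stand alongside each other, since a 1.2-fold lower number from compound 1 to compound 2 (0.09 log units; within the scatter). Compound 3 `O=C(/N=C(/NC(=O)c1cnc2ccccc2c1)[Se]Cc1ccccc1)c1cnc2ccccc2c1` is not yet measured. It differs from compound 2 by a group of 8 heavy atoms (7 carbon, 1 selenium; one six-membered aromatic ring of carbon only) in place of a group of 2 heavy atoms (1 carbon, 1 sulfur; no ring), on a carbon with a double bond to nitrogen. Among the compounds with values here, the one measured step, from compound 1 to compound 2, exchanges selenium for sulfur on the same carbon and stays within the scatter; no measured pair addresses the exchange of methyl for benzyl, so the direction of that part is unknown here. The expectation is therefore a step of a 1.2-fold lower number from compound 2 to compound 3 (0.08 log units; within the scatter) in this assay, not clearly beyond the scatter, with a wide range. Compound 3 is estimated at 35000 nM in this assay, between 12000 nM and 100000 nM.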

Compound 3, concentration for total growth inhibition: > 100000 nM
Compound 3 gave a limit, no number (the forecaster's own chance of this, stated with the estimate: 10%); at least 2.8-fold (0.45 log units) between middle value and limit.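

In this assay, going by these compounds alone, compound 3 gives > 100000 nM, which is a limit of the assay and not a number, so the reading marks only where the scale ends: the limit of > 100000 nM in this assay, at which 1 of the 3 values shown sits. On the carbon with a double bond to nitrogen, the change to benzylselanyl gives the first step beyond the scatter at this position, with an at least 2.3-fold higher number from compound 2 to compound 3 (0.37 log units; beyond the scatter). Phenyl in place of hydrogen on a saturated chain carbon bound to a selenium atom, taken alone, gives an at least 1.9-fold higher number from compound 1 to compound 3 (0.28 log units; that floor lies within the scatter), so this step does not by itself establish a change.

Going by these compounds, how far compound 3 lies past its limit stays open. Also open, on these data alone, is whether benzylsulfanyl or a longer saturated chain with no ring would read like compound 3 or like compound 2 in this assay.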